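The source may hold more compounds than are shown below. What is called first, only, known or untested is meant among the compounds shown, and "the series" means these compounds.

Measured so far:
- compound 1, `CC(C)(C)c1cc(NC(=O)[C@@H]2CCCCN2C2CC2)no1`: 0.183 h
- compound 2, `CC(C)(C)c1cc(NC(=O)[C@@H]2CCCCN2C(=O)c2ccc(Cl)cc2)no1`: 1.25 h

In an ADME assay (liver) for metabolic stability, with Liver microsome (Homo sapiens) as the target, read by LC-MS, using microsomes and NADPH, tested at 1 uM (on this read-out higher numbers stand for a longer-lived compound and lower numbers for a shorter-lived compound), compound 1 gives the lower of the two numbers, while compound 2 gives the higher one; the step of a 6.8-fold higher number from compound 1 to compound 2 (0.83 log units; beyond the scatter) came with a (4-chlorophenyl)carbonyl in place of a cyclopropyl on an amine nitrogen in a ring. Compound 3, `CC(C)(C)c1cc(NC(=O)[C@@H]2CCCCN2C(=O)N2CCSCC2)no1`, carries a different group at the same place: (thiomorpholin-4-yl)carbonyl in place of cyclopropyl on an amine nitrogen in a ring. Among the measured compounds shown here, the only measured step that bears on this change is a 6.8-fold higher number from compound 1 to compound 2 (0.83 log units; beyond the scatter), which exchanged the same cyclopropyl for a carbonyl-bearing group and lengthened the half-life beyond the scatter. The new group is also attached through a carbonyl, so a move in the same direction, possibly somewhat smaller, is expected: a 3.8-fold higher number from compound 1 to compound 3 (0.58 log units; beyond the scatter). Compound 3 is therefore estimated to give 0.7 h in this assay, with a likely range from 0.3 h to 1.8 h.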

Compound 3, half-life: < 0.0834 h
Compound 3 was reported as a limit; the forecaster's own chance of this, stated with the estimate: 5%; middle value at least 8.3-fold (0.92 log units) from the limit.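

A carbonyl on this amine nitrogen in a ring does not by itself go with a longer half-life in this assay: putting (thiomorpholin-4-yl)carbonyl in place of cyclopropyl gives an at least 2.1-fold lower number from compound 1 to compound 3 (0.34 log units; beyond the scatter). What stands on that carbonyl matters greatly, as thiomorpholin-4-yl in place of 4-chlorophenyl gives an at least 14-fold lower number from compound 2 to compound 3 (1.17 log units; beyond the scatter), so the same position can go with results far apart. The figure for compound 3 is a limit and not a number: the limit of < 0.0834 h in this assay, at which 1 of the 3 values shown sits.

As far as these compounds go, whether the sulfur atom or the thiomorpholine ring as a whole goes with the short half-life stays open, and a morpholin-4-yl on the same carbonyl, with oxygen in place of sulfur, would help separate the two. Also open, from the compounds shown here alone, is whether the chlorine of the 4-chlorophenyl counts, which an unsubstituted phenyl would address.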